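Carboxy in place of methyl on a saturated chain carbon

The compounds below may be only part of what the source reports. "The series", "measured", "known", "first", "only" and "open" are said of these compounds alone.

Among the compounds with values here, compound 2 `CCCCOC(=O)OCC1OC(n2cc(C)c(=O)[nH]c2=O)CC1N=[N+]=[N-]` stands highest of the two numbers measured so far in a physicochemical assay for lipophilicity (a lower number here means a more polar compound, a higher number a more lipophilic compound), giving 1.02; its only neighbour, compound 1 `Cc1cn(C2CC(N=[N+]=[N-])C(COC(=O)CCCN)O2)c(=O)[nH]c1=O`, gives -0.9. Within the data shown here, the single measured step, a number 1.92 log units higher from compound 1 to compound 2 (beyond the scatter), is the only precedent for a change at this end of the chain. Compound 3 `Cc1cn(C2CC(N=[N+]=[N-])C(COC(=O)OCCCC(=O)O)O2)c(=O)[nH]c1=O` is not yet measured. It differs from compound 2 by carboxy in place of methyl on a saturated chain carbon, three bonds along the chain from an oxygen next to a carbonyl group. Among the measured compounds shown here, no measured pair shows a carboxy entering, so the precedent is indirect: it shows only that exchanging groups three bonds along the chain from the oxygen next to the carbonyl group can move the partition coefficient by a large amount. For compound 3 a large downward step is expected, namely a number 1.82 log units lower from compound 2 to compound 3 (beyond the scatter). The estimate for compound 3 is -0.8, with a range from -1.8 to 0.2.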

Compound 3, partition coefficient: -0.55
Beside the measured number, compound 3's estimate is 0.25 log units below it; measured number inside the range.
By their numbers in this assay, from the lowest: compound 1; then compound 3; then compound 2.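

In this assay the carboxy now has a direct precedent at this place, three bonds along the chain from an oxygen next to a carbonyl group: replacing methyl gives a number 1.57 log units lower from compound 2 to compound 3 (beyond the scatter) and this large step replaces the indirect reading of the earlier pair. The comparison of the two chain ends gives only a number 0.35 log units higher from compound 1 to compound 3 (beyond the scatter) and this modest step is smaller than either step leading to compound 2, so among these three compounds only compound 2 stands well apart. Nothing available accounts for the size of either step.

Open, on these data alone, is how an amine at this same place would compare with the carboxy on an otherwise unchanged chain. Also open, as far as these compounds go, is whether a shorter or longer chain ending in carboxy would give a step of similar size.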